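Chloro for Nitro at the Limit of an Assay

The source may hold more compounds than are shown below. What is called first, only, known or untested is meant among the compounds shown, and "the series" means these compounds.

Compound 1 `O=C1OCC[C@@H]1NC(=S)SCCOc1ccc([N+](=O)[O-])cc1` is measured in a functional assay on MCF7 cells (Homo sapiens) for antiproliferative activity, read by MTT assay, with a stated time of 72 h; a higher number here means a weaker inhibitor, a lower number a stronger inhibitor. In this test, compound 1 gives > 64000 nM, which is a limit and not a number. Two further compounds provide the only context. Compound 2 `O=C(COc1ccc(C(=O)/C=C/c2ccc(F)cc2)cc1)N[C@H]1CCOC1=O` gives > 64000 nM, also a limit. Compound 3 `O=C(CNc1ccccc1Cl)N[C@H]1CCOC1=O` gives > 64000 nM, again a limit. Compound 1 therefore has no measured number that would rank it against the others, and the whole picture so far is the limit of > 64000 nM in this assay, at which 3 of the 3 values shown sit. For the measured compounds named here, no two measured compounds differ in just one place, so no direct comparison guides the next prediction.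

Compound 4 `O=C1OCC[C@@H]1NC(=S)SCCOc1ccc(Cl)cc1` keeps the structure of compound 1 except for one change: chloro in place of nitro on an aromatic carbon, para to a large group (chloro in place of nitro on an aromatic carbon). This is a single substitution, and the only starting point is the limit of compound 1 at > 64000 nM, so a large gain in this assay is not expected. The likeliest outcome is no change beyond the scatter, with any small shift expected towards stronger inhibition. The expected step is an at least 1.2-fold lower number from compound 1 to compound 4 (0.10 log units; that floor lies within the scatter). For compound 4, the estimated value is 50000 nM, with an expected range of 20000 nM to 64000 nM.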

Compound 4, half-maximal inhibitory concentration: 50500 nM
Compound 4: middle estimate off by 1.0-fold (0.00 log units), on the low side; the range from low to high includes it.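

In this assay, chloro in place of nitro on an aromatic carbon, para to a large group, gives an at least 1.2-fold lower number from compound 1 to compound 4 (0.10 log units; that floor lies within the scatter). Compound 1 gives > 64000 nM, which is a limit and not a number. The true size of the step therefore stays unknown, and its floor does not establish a gain beyond the usual scatter, but compound 4 is the only compound shown with a measured number, so this position on the ring can carry a change that brings a compound into the readable range of the test, against this background: the limit of > 64000 nM in this assay, at which 3 of the 4 values shown sit.

As far as these compounds go, it remains open how far the true step reaches and whether other groups at this place on the ring, such as methoxy, an amine or a carboxylic acid, would give a lower number than compound 4 or none at all. From the compounds shown here alone, it is equally open whether a longer chain in place of the one that links the ring to the sulfur in compound 4 would keep the value in the readable range.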